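Stability of an epoxide on a bis-trifluoromethyl aryl core

The source may report more compounds than this note shows. Statements on the series, on what has been measured and on what is new or still open speak of the compounds shown alone.

Measured compounds:
compound 1, `C=CC(=O)Nc1cc(C(F)(F)F)cc(C(F)(F)F)c1`, 5.3 h
compound 2, `O=C(CBr)c1cc(C(F)(F)F)cc(C(F)(F)F)c1`, < 0.017 h

In an ADME assay for pharmacokinetics, read by HPLC, in phosphate buffer, with a stated time of 72 h, at pH 7.4, tested at 250 uM (on this read-out lower numbers stand for a shorter-lived compound and higher numbers for a longer-lived compound), compound 1 gives 5.3 h, the only plain number shown. For compound 2 this assay reports a limit, < 0.017 h, not a number. Within the data shown here, the step of an at least 310-fold lower number from compound 1 to compound 2 (2.49 log units; beyond the scatter) is the only measured step, and it rests on (the limit of < 0.017 h in this assay, at which 1 of the 2 values shown sits).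

Compound 3, `FC(F)(F)c1cc(C2CO2)cc(C(F)(F)F)c1`, differs from compound 1 by oxiran-2-yl in place of (vinylcarbonyl)amino on an aromatic carbon. Among the measured compounds shown here, no measured step swaps an amide for a three-membered ring, so the large step from compound 1 to compound 2 is only a rough guide; it shows that a change at this aromatic carbon can move this assay a long way. An oxiran-2-yl group is expected to sit nearer compound 1 than compound 2, with the step of a 3.8-fold higher number from compound 1 to compound 3 (0.58 log units; beyond the scatter) expected to be modest. Compound 3 is therefore estimated at 20 h, within 4 h to 100 h.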

Compound 3, half-life: > 50 h
Compound 3: a limit, no number; the forecaster's own chance of this, stated with the estimate: 25%; middle value at least 2.5-fold (0.39 log units) from the limit.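

In this assay compound 3 gives > 50 h, which is a limit of the assay and not a number. Among these compounds, until now, the only measured change at this aromatic carbon lowered the half-life, whereas oxiran-2-yl in place of (vinylcarbonyl)amino gives an at least 9.4-fold higher number from compound 1 to compound 3 (0.97 log units; beyond the scatter), so a change here can also raise it. Oxiran-2-yl in place of (bromomethyl)carbonyl gives an at least 2900-fold higher number from compound 2 to compound 3 (3.46 log units; beyond the scatter), which widens the span seen at this one position, although both ends of that span are limits rather than numbers: the limit of > 50 h in this assay, at which 1 of the 3 values shown sits.

Going by these compounds, how far the true half-life of compound 3 lies beyond its limit remains open. So does whether the oxygen of the three-membered ring matters, which a close relative such as an aziridine ring, with nitrogen in place of that oxygen, could test.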